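Fluoro on the phenyl ring in the ethyl amide series

A few compounds are considered here, and "the series" means these few. Any claim that something is new, unique, unknown or untested is made for them only; others in the source may bear on it.

Measured so far in a functional assay on A549 cells (Homo sapiens) for antiproliferative activity, read by MTT assay, with a stated time of 72 h; on this read-out lower numbers stand for stronger inhibition and higher numbers for weaker inhibition:
compound 1 `CNC(=O)c1cc(Oc2ccc(NC(=O)c3cc4cccnc4n(-c4ccccc4)c3=O)cc2)ccn1`: 200 nM
compound 2 `CNC(=O)c1cc(Oc2ccc(NC(=O)c3cc4cccnc4n(-c4ccccc4F)c3=O)cc2)ccn1`: 610 nM
compound 3 `CCNC(=O)c1cc(Oc2ccc(NC(=O)c3cc4cccnc4n(-c4ccccc4)c3=O)cc2)ccn1`: 160 nM

Compound 3 has the lowest of the three numbers in this assay. Its step from compound 1, a 1.3-fold lower number from compound 1 to compound 3 (0.10 log units; within the scatter), is within the scatter, so no order between compound 1 and compound 3 is claimed. Compound 2 stands furthest from compound 3, and that gap is beyond the scatter.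

Compound 4 `CCNC(=O)c1cc(Oc2ccc(NC(=O)c3cc4cccnc4n(-c4ccccc4F)c3=O)cc2)ccn1` differs from compound 3 by fluoro in place of hydrogen on an aromatic carbon. For the measured compounds named here, one measured step bears directly on this change: a 3.1-fold higher number from compound 1 to compound 2 (0.48 log units; beyond the scatter), the same fluoro for hydrogen exchange on the same phenyl ring, with the methyl amide in place of the ethyl amide. That step was modest but beyond the scatter, toward weaker inhibition. The amide change itself, a 1.3-fold lower number from compound 1 to compound 3 (0.10 log units; within the scatter), was within the scatter, which gives no ground for expecting the fluoro step to read differently on the ethyl amide. A step of about the same size and direction is therefore expected, a 3.1-fold higher number from compound 3 to compound 4 (0.49 log units; beyond the scatter).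

Compound 4 is estimated to give 500 nM in this assay, with a range from 250 nM to 1000 nM.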

Compound 4, half-maximal inhibitory concentration: 490 nM
For compound 4 the middle estimate is 1.0-fold (0.01 log units) above the measured one; low and high end bracket the measured number.
By their numbers in this assay, from the lowest: compounds 3 and 1 (each within the scatter of the next); then compounds 4 and 2 (each within the scatter of the next).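

In this assay, the phenyl to 2-fluorophenyl change now reads on both amides: with the ethyl amide it gives a 3.1-fold higher number from compound 3 to compound 4 (0.49 log units; beyond the scatter) and matches the step seen with the methyl amide, so in these compounds the size of the fluoro step does not vary with the amide (the same change on two cores in this assay, a 3.1-fold higher number (0.48 log units; beyond the scatter) from compound 1 to compound 2 and a 3.1-fold higher number (0.49 log units; beyond the scatter) from compound 3 to compound 4, 1.0-fold (0.00 log units) apart, within the scatter of two such steps). The amide change can now be read with the 2-fluorophenyl in place as well, where it gives a 1.2-fold lower number from compound 2 to compound 4 (0.10 log units; within the scatter) and again stays without a readable effect, as it did on the unsubstituted phenyl (the same change on two cores in this assay, a 1.3-fold lower number (0.10 log units; within the scatter) from compound 1 to compound 3 and a 1.2-fold lower number (0.10 log units; within the scatter) from compound 2 to compound 4, 1.0-fold (0.00 log units) apart, within the scatter of two such steps). Across compounds 1, 2, 3 and 4, the two changes therefore behave independently: the fluoro ortho to a large group accounts for the shift beyond the scatter, while the methyl to ethyl exchange accounts for none.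

From the compounds shown here alone, whether chloro or methoxy in the place of the fluoro would give a step of the same size remains open. Going by these compounds, it is also open whether the amide stays this flat with a propyl chain or a chain ending in an amine.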